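Swapping the aryl ketone partner in a pyrazolyl chalcone series

This account rests on a few compounds, and the source may have more. Where it says the series, first, only, none or still open, it means among the compounds named here.

Three compounds have been measured in a functional assay on SK-MEL-28 cells (Homo sapiens) for inhibition, read by sulforhodamine B assay, with a stated time of 48 h; a higher number here means a weaker inhibitor of growth, a lower number a stronger inhibitor of growth:

Compound 1, `COc1ccc(-c2cc(/C=C/C(=O)c3ccc(OC)c(OC)c3)[nH]n2)cc1`, gives 3070 nM.
Compound 2, `COc1cc(-c2cc(/C=C/C(=O)c3ccc(Cl)c(Cl)c3)[nH]n2)cc(OC)c1OC`, gives 66000 nM.
Compound 3, `COc1ccc(-c2cc(/C=C/C(=O)c3cc(OC)c(OC)c(OC)c3)[nH]n2)cc1OC`, gives 4410 nM.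

Compound 2 stands at the highest of the three numbers, and both of the other values lie beyond the scatter below it. Compound 1 and compound 3 carry methoxy-substituted aryl groups on the carbonyl carbon, while compound 2 is the only one bearing the 3,4-dichlorophenyl there.

Compound 4, `COc1ccc(C(=O)/C=C/c2cc(-c3cc(OC)c(OC)c(OC)c3)n[nH]2)cc1OC`, has not yet been measured. It differs from compound 2 in one place: 3,4-dimethoxyphenyl in place of 3,4-dichlorophenyl on a carbonyl carbon. The rest of the molecule, including the 3,4,5-trimethoxyphenyl on the shared core, is kept.

Within the data shown here, no step between two measured compounds reproduces this exact change, so the expectation rests on the spread of the three values. Because compound 1 gives 3070 nM and compound 3 gives 4410 nM, each with a methoxy-bearing aryl group on the carbonyl carbon, compound 4 is expected to move in the same direction, toward a much lower number than compound 2. The estimated step from compound 2 to compound 4 in this assay is a 13-fold lower number from compound 2 to compound 4 (1.12 log units; beyond the scatter), well beyond the scatter.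

Compound 4 is estimated at 5000 nM, with a range from 1500 nM to 20000 nM.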

Compound 4, concentration for total growth inhibition: 3340 nM
Compound 4: middle estimate off by 1.5-fold (0.18 log units), on the high side; the range from low to high includes it.
By their numbers in this assay, from the lowest: compounds 1, 4 and 3 (each within the scatter of the next); then compound 2.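

In this assay, putting 3,4-dimethoxyphenyl in place of 3,4-dichlorophenyl on a carbonyl carbon, with the 3,4,5-trimethoxyphenyl on the shared core kept, gives a 20-fold lower number from compound 2 to compound 4 (1.30 log units; beyond the scatter), a large step. The earlier compounds shown here could not show this, since compound 2 differed from compound 1 and compound 3 in more than one place, whereas this single change now ties a large difference to the group on the carbonyl carbon; compound 4 also lies within the scatter of compound 1, which differs from it only in the aryl group on the shared core. Nothing measured here accounts for the size of the step.

With only these two groups compared directly on the carbonyl carbon, the compounds shown cannot separate the effect of removing the chlorines from that of adding the methoxy groups. They also leave open how an unsubstituted phenyl, a hydroxyphenyl or a dimethylaminophenyl at this place would read in this assay, and whether the same step would appear with a different aryl group on the shared core.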